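A few compounds are considered here, and "the series" means these few. Any claim that something is new, unique, unknown or untested is made for them only; others in the source may bear on it.

Compound 1 `CC[N+](CC)(CC)Cc1ccc2oc(-c3ccccc3Cl)cc(=O)c2c1`: "not determined" (no result reported)
Compound 2 `Cc1cc(Cl)cc2c(=O)cc(-c3ccccc3Cl)oc12`: "not determined" (no result reported)
Compound 3 `CN(C)Cc1cc(Cl)cc2c(=O)cc(-c3ccc([N+](=O)[O-])cc3)oc12`: 56500 nM

In a functional assay on SMMC-7721 cells (Homo sapiens) for cytotoxicity, read by MTT assay, with a stated time of 48 h (on this read-out higher numbers stand for weaker inhibition and lower numbers for stronger inhibition), compound 2 stands without a single number, recorded as "not determined" (no result reported), so it offers no measured starting point. The next structure is compound 4 `CN(C)Cc1cc(Cl)cc2c(=O)cc(-c3ccccc3Cl)oc12`, and the change is dimethylamino in place of hydrogen on a saturated chain carbon bound to an aromatic carbon. Among the compounds with values here, no measured pair shows what this change does, so the size of the step cannot be read from the data. A moderate step towards stronger inhibition is expected, though this is only a tentative judgement. The nearest guide is compound 3, which also carries (dimethylamino)methyl and gives 56500 nM, although it differs from compound 4 in another group. For compound 4 the estimated value is 40000 nM, with an expected range of 12000 nM to 100000 nM.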

Compound 4, half-maximal inhibitory concentration: 1140 nM
Beside the measured number, compound 4's estimate is 35-fold (1.55 log units) above it; the measured number lies below the stated range.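

Within the data shown here, compound 2 has no single number, so no step from it to compound 4 can be read. The compounds shown leave open how much the dimethylamino group itself changes inhibition. No supporting evidence bears on this result.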